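A Second Chloro on the Shared Core

A few compounds are considered here, and "the series" means these few. Any claim that something is new, unique, unknown or untested is made for them only; others in the source may bear on it.

Compound 1 `ClCc1ccccc1Cn1cnc2c(Cl)nc(Cl)nc21` and compound 2 `ClCc1ccccc1Cn1cnc2c(Cl)ncnc21` share one core, while compound 3 `ClCc1cccc(Cn2cnc3c(Cl)ncnc32)c1` has the same atoms joined differently; the difference between the two cores is not broken down here. In a functional assay on T47D cells (Homo sapiens) for cytotoxicity, read by sulforhodamine B assay, with a stated time of 48 h (a lower number here means a stronger inhibitor of growth, a higher number a weaker inhibitor of growth), compound 2 gives 17800 nM, compound 1 gives 1990 nM and compound 3 gives 3020 nM. Going from compound 2 to compound 1 means chloro in place of hydrogen on an aromatic carbon and it brought an 8.9-fold lower number from compound 2 to compound 1 (0.95 log units; beyond the scatter). Compound 4 `ClCc1cccc(Cn2cnc3c(Cl)nc(Cl)nc32)c1` arises from compound 3 by the same change, (chloro in place of hydrogen on an aromatic carbon), made at the same kind of place. Because the earlier step of an 8.9-fold lower number from compound 2 to compound 1 (0.95 log units; beyond the scatter) was seen once only, a somewhat smaller improvement is expected for compound 4, namely a 6.7-fold lower number from compound 3 to compound 4 (0.83 log units; beyond the scatter). Compound 4 is therefore estimated at 450 nM, likely falling between 150 nM and 1400 nM.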

Compound 4, concentration for 50% growth inhibition: 1950 nM
Beside the measured number, compound 4's estimate is 4.3-fold (0.64 log units) below it, and the stated range ends below it.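

In this assay, the added chloro gives a 1.5-fold lower number from compound 3 to compound 4 (0.19 log units; within the scatter), so on this core its effect cannot be told apart from the scatter of repeated measurements. The change did not carry over in size from one core to the other: the same change on two cores in this assay, an 8.9-fold lower number (0.95 log units; beyond the scatter) from compound 2 to compound 1 and a 1.5-fold lower number (0.19 log units; within the scatter) from compound 3 to compound 4, 5.8-fold (0.76 log units) apart, beyond the scatter of two such steps. These two pairs show that the step seen on one core is no safe guide to the step on the other, but they do not show why the two differ or how the change would behave on a further core.

The compounds shown leave open what a group other than chloro, such as an amine or a methoxy group, would do on the aromatic carbon between two ring nitrogen atoms. On these data alone, it also remains open whether either core would respond to such a group in the same way.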